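The source may hold more compounds than are shown below. What is called first, only, known or untested is meant among the compounds shown, and "the series" means these compounds.

In an ADME assay on HaCaT cells (Homo sapiens) for cytotoxicity, read by MTT assay, with a stated time of 72 h (on this read-out lower numbers stand for stronger inhibition and higher numbers for weaker inhibition), compound 1 `Cc1cc(-c2ccccc2)n(/C(N)=N/S(=O)(=O)c2cc(C)c(Cl)cc2SCc2cccc(C(F)(F)F)c2)n1` gives 40000 nM and compound 2 `Cc1cc(S(=O)(=O)/N=C(\N)n2nccc2-c2ccccc2)c(SCc2cccc3ccccc23)cc1Cl` gives 11000 nM; compound 2 thus holds the lower of the two numbers, with compound 1 beyond the scatter from it. Compound 3 `Cc1cc(S(=O)(=O)/N=C(\N)n2nccc2-c2ccccc2)c(SCc2cccc(C(F)(F)F)c2)cc1Cl` differs from compound 2 by one change: 3-(trifluoromethyl)phenyl in place of naphthalen-1-yl on a saturated chain carbon bound to a sulfur. Going by the values given here, compound 3 has not been measured in this assay, and no measured pair differs in that place alone, so no step of the same kind is known. The same 3-(trifluoromethyl)benzyl sits on the different core of compound 1. The value expected for compound 3 is 20000 nM, within a range from 8000 nM to 50000 nM. This corresponds to an expected step of a 1.8-fold higher number from compound 2 to compound 3 (0.26 log units; within the scatter) toward a higher number, one that may still fall within the scatter.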

Compound 3, half-maximal inhibitory concentration: 18000 nM
Compound 3: middle estimate off by 1.1-fold (0.05 log units), on the high side; low and high end bracket the measured number.
By their numbers in this assay, from the lowest: compounds 2 and 3 (each within the scatter of the next); then compound 1.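

In this assay, placing 3-(trifluoromethyl)phenyl for naphthalen-1-yl on a saturated chain carbon bound to a sulfur gives a 1.6-fold higher number from compound 2 to compound 3 (0.21 log units; within the scatter), so the two groups are not told apart at this position. Compound 1 and compound 2 differed in two places, but hydrogen in place of methyl on an aromatic carbon now stands alone as a modest step, a 2.2-fold lower number from compound 1 to compound 3 (0.35 log units; beyond the scatter), which places the clearer difference at that methyl. No measurement here explains either step. From the compounds shown here alone, whether an amine, a carboxylic acid or a longer chain at the sulfur would move the number remains open.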